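This account rests on a few compounds, and the source may have more. Where it says the series, first, only, none or still open, it means among the compounds named here.

Compound 1 `CC1(C)C/C(=N\OC(=O)c2cccc(NC(=O)c3cccc(F)c3)c2)c2c(noc2-c2cccc(F)c2)C1` gives > 25000 nM in a functional assay on MDA-MB-231 cells (Homo sapiens) for antiproliferative activity, read by MTT assay, with a stated time of 72 h (on this read-out lower numbers stand for stronger inhibition and higher numbers for weaker inhibition), a limit of the assay.
Compound 2 `COc1ccc(-c2onc3c2/C(=N/OC(=O)c2cccc(NC(=O)c4cccc(F)c4)c2)CC(C)(C)C3)cc1OC` gives > 25000 nM in this assay, also a limit.

Compound 2 stands only at a limit, and the step that the two limits leave unreadable from compound 1 to compound 2 stays unreadable because of the limit of > 25000 nM in this assay, at which 2 of the 2 values shown sit. Compound 3 `COc1cc(-c2onc3c2/C(=N/OC(=O)c2cccc(NC(=O)c4cccc(F)c4)c2)CC(C)(C)C3)ccc1O` differs from compound 2 by hydrogen in place of methyl on an oxygen on an aromatic ring. Within the data shown here, no measured step bears on this change, so no step beyond the scatter is expected in this assay, and the step that the limit leaves unreadable from compound 2 to compound 3 is estimated to read near nothing. Compound 3 is expected at 30000 nM, range 8000 nM to 100000 nM, most likely again a limit.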

Compound 3, half-maximal inhibitory concentration: > 25000 nM
Compound 3: a limit, no number (the forecaster's own chance of this, stated with the estimate: 75%); the middle value is on the limit's open side.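

No new step can be read among compound 1, compound 2 and compound 3, because each stands only at a limit: the limit of > 25000 nM in this assay, at which 3 of the 3 values shown sit.

The compounds shown leave open which structural change, if any, would give a readable number in this assay.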